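The source may report more compounds than this note shows. Statements on the series, on what has been measured and on what is new or still open speak of the compounds shown alone.

Measured in a functional assay on HCT-116 cells (Homo sapiens) for cytotoxicity, read by sulforhodamine B assay, with a stated time of 48 h; a higher number here means a weaker inhibitor of growth, a lower number a stronger inhibitor of growth:
compound 1 `ClCc1ccccc1Cn1cnc2c(Cl)nc(Cl)nc21` gives 190 nM
compound 2 `ClCc1ccccc1Cn1cnc2c(Cl)ncnc21` gives 1900 nM
compound 3 `ClCc1cccc(Cn2cnc3ncnc(Cl)c32)c1` gives 1770 nM

Compound 1 and compound 2 carry the same side chain and differ only by chloro in place of hydrogen on an aromatic carbon. That single change gave a 10-fold lower number from compound 2 to compound 1 (1.00 log units; beyond the scatter). Compound 3 is built from the same atoms as compound 2, joined differently; the difference between the two cores is not broken down here. In this assay the numbers for compound 3 and compound 2 sit within the scatter of each other, so nothing separates them.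

Compound 4 `ClCc1cccc(Cn2cnc3nc(Cl)nc(Cl)c32)c1` is not yet measured. It differs from compound 3 by chloro in place of hydrogen on an aromatic carbon, the same change that leads from compound 2 to compound 1, at a place described in identical terms. Because the earlier pair showed a 10-fold lower number from compound 2 to compound 1 (1.00 log units; beyond the scatter), compound 4 is expected to show a step of about an 8.0-fold lower number from compound 3 to compound 4 (0.91 log units; beyond the scatter). The estimate for compound 4 is 220 nM, with a likely span from 90 nM to 550 nM. This rests on one measured pair only, and a different side chain could shift the outcome.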

Compound 4, concentration for 50% growth inhibition: 750 nM
For compound 4 the middle estimate is 3.4-fold (0.53 log units) below the measured one, outside the stated range (above it).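

In this assay chloro in place of hydrogen on an aromatic carbon again lowers the number, with a 2.4-fold lower number from compound 3 to compound 4 (0.37 log units; beyond the scatter) on this core, so the direction of the earlier step is repeated. The size of the step does not carry over from one core to the other: the same change on two cores in this assay, a 10-fold lower number (1.00 log units; beyond the scatter) from compound 2 to compound 1 and a 2.4-fold lower number (0.37 log units; beyond the scatter) from compound 3 to compound 4, 4.2-fold (0.63 log units) apart, beyond the scatter of two such steps. Two pairs cannot show which difference between the two cores or their side chains sets the size of the step, nor whether the same direction would hold on a further core in this series.

The compounds shown carry only chloro or hydrogen at the place between two ring nitrogen atoms, so the outcome with an amine, a methoxy group or a fluoro group there remains open. Also open, on these data alone, is how the numbers would move if the chlorine of the chloromethyl group on the side chain gave way to a hydroxyl group or an amine.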